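The source may hold more compounds than are shown below. What is called first, only, known or untested is meant among the compounds shown, and "the series" means these compounds.

Three compounds have been measured in a functional assay on the whole organism for inhibition, with Rattus norvegicus as the target, read by paw edema; on this read-out lower numbers stand for an effect already at smaller amounts and higher numbers for an effect only at larger amounts of compound:

Compound 1 `O=C(O)c1cc(-c2ccns2)ccc1O` gives 80 mg/kg.
Compound 3 `CCCCOC(=O)Oc1ccc(-n2cccc2)cc1C(=O)O` gives 52 mg/kg.
Compound 2 `O=C(O)c1cc(-c2ccncn2)ccc1O` gives > 200 mg/kg, which is a limit of the assay rather than a number.

Of the two real numbers in this assay, compound 1 carries the larger printed figure, but its gap to compound 3 is within the usual scatter, so the two cannot be separated. The only limit seen is the limit of > 200 mg/kg in this assay, at which 1 of the 3 values shown sits.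

Compound 4 `O=C(O)c1cc(-c2nccs2)ccc1O` has the same atoms as compound 1, joined differently: 1,3-thiazol-2-yl in place of 1,2-thiazol-5-yl on an aromatic carbon. Among the measured compounds shown here, no step between two measured compounds of this kind exists, so the size of the change in this assay can only be guessed. Because compound 1 gives 80 mg/kg and the swap keeps the ring size and the hetero atoms, no step beyond the scatter is expected in either direction. Compound 4 is therefore estimated at 80 mg/kg, within a range of 35 mg/kg to 200 mg/kg. The expected step of no change at the digits printed from compound 1 to compound 4 (within the scatter) is thus small.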

Compound 4, dose for half-maximal effect: > 250 mg/kg
Compound 4: no number, only a limit; the forecaster's own chance of this, stated with the estimate: 25%; middle value at least 3.1-fold (0.49 log units) from the limit.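

In this assay the swap of 1,2-thiazol-5-yl for 1,3-thiazol-2-yl gives an at least 3.1-fold higher number from compound 1 to compound 4 (0.49 log units; beyond the scatter) even though the two rings have the same atoms and the same counts of hydrogen-bond donors and acceptors. Compound 4 gives > 250 mg/kg as a limit of the assay and not as a number, so the full size of this step cannot be read. Among the compounds shown here, this is the first step between measured compounds, and it shows that at this position, para to the hydroxy group, how the ring atoms are joined can matter on its own.

The compounds shown do not tell which part of this rearrangement is responsible for the step. They also leave open how other groups at this position would behave, such as a 1,3-thiazol-5-yl ring, a plain phenyl ring or an amine.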